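This account rests on a few compounds, and the source may have more. Where it says the series, first, only, none or still open, it means among the compounds named here.

Working notes on the series, an ADME assay on HeLa cells (Homo sapiens) for cytotoxicity, read by trypan blue exclusion, with a stated time of 24 h; on this read-out lower numbers stand for stronger inhibition and higher numbers for weaker inhibition.

Compound 1 `COc1ccc(/C=C/C(=O)c2ccc(OCc3cn(CCNc4ccnc5cc(Cl)ccc45)nn3)cc2)cc1` and compound 2 `COc1ccc(/C=C/C(=O)c2ccc(OCc3cn(CCNc4ccnc5cc(Cl)ccc45)nn3)cc2)cc1OC` share one core; compound 3 `COc1ccc(C2CC(c3ccc(OCc4cn(CCNc5ccnc6cc(Cl)ccc56)nn4)c(OC)c3)=NN2C(C)=O)cc1` and compound 4 `COc1ccc(C2CC(c3ccc(OCc4cn(CCNc5ccnc6cc(Cl)ccc56)nn4)cc3)=NN2C(C)=O)cc1` share another, and the difference between the two cores is not broken down here. In this assay compound 1 gives 35600 nM, compound 2 gives 12700 nM and compound 3 gives 32800 nM. The change from compound 2 to compound 1 is hydrogen in place of methoxy on an aromatic carbon, and it made a 2.8-fold higher number from compound 2 to compound 1 (0.45 log units; beyond the scatter). The change from compound 3 to compound 4 is hydrogen in place of methoxy on an aromatic carbon; it is the same kind of change, but the surroundings differ: in compound 2 the carbon is ortho to a methoxy group, in compound 3 it is ortho to a large group, so it is not the same change. Compound 3 and compound 1 sit within the scatter of each other, while compound 2 lies beyond it on the lower side.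

Resting only on the step from compound 2 to compound 1, the number for compound 4 is expected to rise by a 1.7-fold higher number from compound 3 to compound 4 (0.22 log units; within the scatter). Compound 4 is therefore estimated at 55000 nM, with a range expected between 25000 nM and 120000 nM.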

Compound 4, half-maximal inhibitory concentration: 29200 nM
For compound 4 the middle estimate is 1.9-fold (0.27 log units) above the measured one; measured number inside the range.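

In this assay, hydrogen in place of methoxy on an aromatic carbon gives a 1.1-fold lower number from compound 3 to compound 4 (0.05 log units; within the scatter). Set beside the earlier step, the change does not carry over between these two cores at the same size: the same change on two cores in this assay, a 2.8-fold higher number (0.45 log units; beyond the scatter) from compound 2 to compound 1 and a 1.1-fold lower number (0.05 log units; within the scatter) from compound 3 to compound 4, 3.1-fold (0.50 log units) apart, beyond the scatter of two such steps. The comparison shows that, within these four compounds, the step on one core was a poor guide to the step on the other; it rests on one pair per core, however, and it does not show what sets the gap, whether the shared core differences or the different surroundings of the aromatic carbon, nor how the change would behave on any further core.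

On these data alone, it remains open whether a hydroxyl group, a chlorine atom or an ethoxy group on that aromatic carbon would also give steps that differ between the two cores. As far as these compounds go, it also remains open whether a second pair on each core would give steps of the same size as these.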